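The source may hold more compounds than are shown below. What is called first, only, known or untested is meant among the compounds shown, and "the series" means these compounds.

Going by the values given here, compound 1 `COC(OC)C1=C(C(=O)OC/C=C/c2ccccc2)C(c2cccc(Cl)c2)C(C(=O)O)=C(C)N1` is one of two compounds measured in an assay on thoracic aorta for inhibition of Voltage-gated L-type calcium channel (Rattus norvegicus) (on this read-out lower numbers stand for stronger inhibition and higher numbers for weaker inhibition), so far; in this assay compound 1 gives 8100 nM, the higher of the two numbers. Its partner compound 2 `COC(OC)C1=C(C(=O)OC/C=C/c2ccccc2Cl)C(c2cccc(Cl)c2)C(C(=O)O)=C(C)N1` differs from it in a single place, a chloro in place of a hydrogen on an aromatic carbon of the phenyl attached to the ester chain, and compound 2 gives 700 nM. That single change produced a 12-fold lower number from compound 1 to compound 2 (1.06 log units; beyond the scatter), a step well outside the scatter of repeated measurements.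

Compound 3 `COc1ccccc1/C=C/COC(=O)C1=C(C(OC)OC)NC(C)=C(C(=O)O)C1c1cccc(Cl)c1` changes compound 1 at the same kind of place, but with a different group: methoxy in place of hydrogen on an aromatic carbon. Among the compounds with values here, only one measured step bears on this change, the one from compound 1 to compound 2, and it was large. A methoxy is not a chloro, so a smaller step is expected here, while still in the same direction as that of compound 2. The step from compound 1 to compound 3 is expected to be a 3.2-fold lower number from compound 1 to compound 3 (0.51 log units; beyond the scatter). On that basis, compound 3 is estimated to give 2500 nM in this assay, within a range from 800 nM to 6500 nM.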

Compound 3, half-maximal inhibitory concentration in the Voltage-gated L-type calcium channel assay: 5900 nM
Beside the measured number, compound 3's estimate is 2.4-fold (0.37 log units) below it; the range from low to high includes it.
By their numbers in the Voltage-gated L-type calcium channel assay, from the lowest: compound 2; then compounds 3 and 1 (each within the scatter of the next).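

In the Voltage-gated L-type calcium channel assay, compound 1 gives 8100 nM and compound 3 gives 5900 nM, so placing a methoxy on this aromatic carbon gives a result that cannot be told apart from hydrogen: a 1.4-fold lower number from compound 1 to compound 3 (0.14 log units; within the scatter). Exchanging the chloro for methoxy at the same place gives a clear difference, an 8.4-fold higher number from compound 2 to compound 3 (0.93 log units; beyond the scatter), so among these three compounds, the identity of the group matters here, and filling the place is not enough to give the lower number seen with chloro. In a physicochemical assay for lipophilicity (on this read-out lower numbers stand for lower lipophilicity and higher numbers for higher lipophilicity), compound 1 gives 1.29 and compound 3 gives 1.2, so the methoxy change also stays small, a number 0.09 log units lower from compound 1 to compound 3 (within the scatter), and nothing measured here accounts for the different outcomes with chloro and methoxy.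

With only chloro and methoxy to compare, these compounds leave open whether a fluoro, a bromo or a methyl at the same place would follow chloro, follow methoxy or give a different result. They also leave open whether chloro or methoxy would act the same way on the other carbons of this aromatic ring, or whether a change at this place would carry over to a compound with a different core.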